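Working notes: from compound 2 to compound 3

The source may report more compounds than this note shows. Statements on the series, on what has been measured and on what is new or still open speak of the compounds shown alone.

Measured so far:
compound 1 `NC(=O)c1c(NC(=O)c2ccccc2Cl)sc2c1CCN(C(=S)Nc1ccccc1Br)C2`, 10800 nM
compound 2 `NC(=O)c1c(NC(=O)c2ccccc2C(F)(F)F)sc2c1CCN(C(=S)Nc1ccccc1Br)C2`, 23900 nM

Both numbers come from a functional assay on MKN-74 cells (Homo sapiens) for antiproliferative activity, with a stated time of 24 h; on this read-out higher numbers stand for weaker inhibition and lower numbers for stronger inhibition. Going by the values given here, compound 2 gives the highest of the two numbers; its only neighbour is compound 1, and the step of a 2.2-fold higher number from compound 1 to compound 2 (0.34 log units; beyond the scatter) is modest. Compound 3 `Cc1ccccc1C(=O)Nc1sc2c(c1C(N)=O)CCN(C(=S)Nc1ccccc1Br)C2` differs from compound 2 by methyl in place of trifluoromethyl on an aromatic carbon, on an aromatic carbon of a six-membered aromatic ring of carbon only, ortho to a large group. Among the compounds with values here, only that one measured step bears on this change, and it was modest, so a modest step downward is expected here, a 2.0-fold lower number from compound 2 to compound 3 (0.30 log units; within the scatter). For compound 3 the estimate is 12000 nM, within 5000 nM to 30000 nM.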

Compound 3, half-maximal inhibitory concentration: > 50000 nM
Compound 3: a limit, no number (the forecaster's own chance of this, stated with the estimate: 10%); middle value at least 4.1-fold (0.61 log units) away from the limit.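

On this assay methyl in place of trifluoromethyl gives an at least 2.0-fold higher number from compound 2 to compound 3 (0.32 log units; beyond the scatter) and methyl in place of chloro gives an at least 4.6-fold higher number from compound 1 to compound 3 (0.66 log units; beyond the scatter) so at this aromatic carbon, ortho to a large group, methyl gives weaker inhibition than either group before it, an order the earlier pair could not show. Compound 3 stands as a limit and not a number, so the true size of both steps stays unknown: the limit of > 50000 nM in this assay, at which 1 of the 3 values shown sits.

Open, as far as these compounds go, is whether an amine, a hydroxyl or a methoxy on this carbon would match or pass compound 1. Also open, from the compounds shown here alone, is whether chloro, trifluoromethyl and methyl keep this order on other carbons of the same ring.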